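Methyl on the pendant phenyl, compared across two cores

This account rests on a few compounds, and the source may have more. Where it says the series, first, only, none or still open, it means among the compounds named here.

All values below come from a functional assay on MKN-45 cells (Homo sapiens) for cytotoxicity, read by MTT assay, with a stated time of 72 h; on this read-out lower numbers stand for stronger inhibition and higher numbers for weaker inhibition.

compound 1, `COc1cc2c(Oc3ccc(NC(=O)c4cc(-c5ccccc5)ccn4)cc3F)ccnc2cc1OCCCN1CCN(C)CC1`: 150 nM
compound 2, `COc1cc2c(Oc3ccc(NC(=O)c4cc(-c5ccccc5C)ccn4)cc3F)ccnc2cc1OCCCN1CCN(C)CC1`: 240 nM
compound 3, `COc1cc2c(Oc3ccc(NC(=O)c4nccc(-c5ccccc5)n4)cc3F)ccnc2cc1OCCCN1CCCC1`: 1360 nM

Compound 1 and compound 2 share one core; compound 3 carries a different core, and the difference between the two cores is not broken down here. In this assay compound 3 stands with the highest number of the three, beyond the scatter against both compound 2 and compound 1.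

The step from compound 1 to compound 2 is methyl in place of hydrogen on an aromatic carbon and gives a 1.6-fold higher number from compound 1 to compound 2 (0.20 log units; within the scatter). Compound 4, `COc1cc2c(Oc3ccc(NC(=O)c4nccc(-c5ccc(C)cc5)n4)cc3F)ccnc2cc1OCCCN1CCCC1`, is not yet measured; it differs from compound 3 by methyl in place of hydrogen on an aromatic carbon. The two changes are the same kind of change but not the same: in compound 2 the methyl sits ortho to a large group, whereas in compound 4 it sits para to a large group, and compound 4 is built on the core of compound 3 rather than that of compound 1.

Going by the values given here, with only one earlier instance to go on, the step from compound 3 to compound 4 in this assay is expected to be a 1.3-fold higher number from compound 3 to compound 4 (0.10 log units; within the scatter), resting on compound 1 to compound 2 having given a 1.6-fold higher number from compound 1 to compound 2 (0.20 log units; within the scatter). The estimate for compound 4 is therefore 1700 nM, with a range from 800 nM to 3600 nM.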

Compound 4, half-maximal inhibitory concentration: 240 nM
The estimate for compound 4 lay 7.1-fold (0.85 log units) above the measured number, and the stated range ends above it.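

In this assay, phenyl to 4-methylphenyl on the core of compound 3 gives a 5.7-fold lower number from compound 3 to compound 4 (0.75 log units; beyond the scatter), and this step does not match the earlier methyl step on the core of compound 1, so the effect of adding a methyl to the pendant phenyl cannot be carried as a fixed increment from one core to the other: the same change on two cores in this assay, a 1.6-fold higher number (0.20 log units; within the scatter) from compound 1 to compound 2 and a 5.7-fold lower number (0.75 log units; beyond the scatter) from compound 3 to compound 4, 9.1-fold (0.96 log units) apart, beyond the scatter of two such steps

This does not show what separates the two steps, since the pairs differ in the place of the methyl on the phenyl, in the core and in the amine at the end of the side chain, and these differences cannot be separated with the compounds at hand. Each step also rests on a single pair in one cell assay, so no general rule for methyl in this series follows from them.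

Still open, from the compounds shown here alone, is whether 4-methylphenyl on the core of compound 1 would give a step closer to that from compound 3 to compound 4, which would separate the place of the methyl from the core. Also open, going by these compounds, is whether the result for compound 4 is particular to methyl or extends to other groups in that place, such as ethyl, chloro or methoxy.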